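This account rests on a few compounds, and the source may have more. Where it says the series, first, only, none or still open, it means among the compounds named here.

Working notes on the series.

Compound 1 `CN1C(=O)C=C(Cl)C1(O)c1ccccc1` gives 2500 nM in an assay on cell membranes for displacement of a labelled ligand from Cholecystokinin receptor type A (Rattus norvegicus), read by CCK-8 assay, with a stated time of 2 h; a higher number here means a weaker inhibitor, a lower number a stronger inhibitor. Compound 2 `CN1C(=O)C=C(Cl)C1(O)c1ccc(Cl)cc1` carries chloro in place of hydrogen on an aromatic carbon relative to compound 1; in this assay compound 2 gives 2000 nM; the step of a 1.3-fold lower number from compound 1 to compound 2 (0.10 log units; within the scatter) lies within the scatter, so the two values cannot be told apart. Compound 3 `O=C1C=C(Cl)C(O)(c2ccccc2)N1C1CC1` differs from compound 1 by cyclopropyl in place of methyl on an amide-type nitrogen in a ring; in this assay compound 3 gives 7500 nM; the step of a 3.0-fold higher number from compound 1 to compound 3 (0.48 log units; beyond the scatter) is a modest weakening. Compound 3 holds the highest of the three numbers, and its distance from both compound 1 and compound 2 is beyond the scatter.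

Compound 4 `O=C1C=C(Cl)C(O)(c2ccc(Cl)cc2)N1C1CC1` has not yet been measured. It differs from compound 3 by chloro in place of hydrogen on an aromatic carbon. This is the same kind of change as chloro in place of hydrogen on an aromatic carbon, not the same change: the surroundings are described once as para to a group of 9 heavy atoms and once as para to a large group. The two cores differ by cyclopropyl in place of methyl on an amide-type nitrogen in a ring. Among the measured compounds shown here, the only precedent for the change is a 1.3-fold lower number from compound 1 to compound 2 (0.10 log units; within the scatter), a step inside the scatter. On that single precedent, compound 4 is expected to move from compound 3 by about a 1.3-fold lower number from compound 3 to compound 4 (0.10 log units; within the scatter) in this assay, which would again be within the scatter. Compound 4 is therefore estimated at about 6000 nM in this assay, expected to fall between 3000 nM and 14000 nM. The measured number is awaited.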

Compound 4, half-maximal inhibitory concentration: 4000 nM
The estimate for compound 4 lay 1.5-fold (0.18 log units) above the measured number, and the stated range covers the measured number.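

In this assay the new step for chloro in place of hydrogen on an aromatic carbon reads a 1.9-fold lower number from compound 3 to compound 4 (0.27 log units; within the scatter), and this change cannot be told apart between the two cores: the same change on two cores in this assay, a 1.3-fold lower number (0.10 log units; within the scatter) from compound 1 to compound 2 and a 1.9-fold lower number (0.27 log units; within the scatter) from compound 3 to compound 4, 1.5-fold (0.18 log units) apart, within the scatter of two such steps The new step for cyclopropyl in place of methyl on the amide-type nitrogen reads a 2.0-fold higher number from compound 2 to compound 4 (0.30 log units; within the scatter), and although the earlier step for this change lay beyond the scatter and this one lies within it, the two steps do not differ measurably: the same change on two cores in this assay, a 3.0-fold higher number (0.48 log units; beyond the scatter) from compound 1 to compound 3 and a 2.0-fold higher number (0.30 log units; within the scatter) from compound 2 to compound 4, 1.5-fold (0.18 log units) apart, within the scatter of two such steps Both changes therefore carry from one core to the other without a detectable difference, but this rests on a single set of four compounds, shows no real effect of chloro on either core, and cannot exclude a small dependence of either change on the other.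

The compounds shown leave open whether a longer chain on the amide-type nitrogen, or an amine or a carboxylic acid in place of chloro on the aromatic ring, would follow the same pattern. They also leave open how the number in this assay responds to replacing the hydroxyl group or the ring chloro of the shared core.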